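A few compounds are considered here, and "the series" means these few. Any claim that something is new, unique, unknown or untested is made for them only; others in the source may bear on it.

Measured so far in an ADME assay on microsomes from liver (Mus musculus, strain CD-1) for metabolic stability, read by LC-MS, tested at 2 uM; a lower number here means that the compound disappears faster, a higher number that the compound lasts longer:
- Compound 1 `CN1CCC(NC(=O)c2ccncc2Nc2cc(-c3ccc4ccn(C)c4c3)c3nccnc3c2)CC1`: > 1 h, a limit of the assay and not a number.
- Compound 2 `CC(=O)N1CCC(NC(=O)c2ccncc2Nc2cc(-c3ccc4ccn(C)c4c3)c3nccnc3c2)CC1`: 0.117 h.

For the measured compounds named here, compound 2 holds the only exact number so far in this assay, at 0.117 h. Going by the values given here, the single measured step is an at least 8.5-fold lower number from compound 1 to compound 2 (0.93 log units; beyond the scatter), and it swaps methyl for acetyl on the ring nitrogen.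

Compound 3 `CN1CCC(NC(=O)c2ccncc2Nc2cc(-c3ccc4ccn(C)c4c3)c3nccnc3c2)CC1=O` keeps the shared core and changes the group on the amide-type nitrogen. 1-Methyl-2-oxopiperidin-4-yl takes the place of 1-acetylpiperidin-4-yl (1-methyl-2-oxopiperidin-4-yl in place of 1-acetylpiperidin-4-yl on an amide-type nitrogen). The measured step bears on this change only in part. Compound 3 regains a methyl, as in compound 1, but it also keeps a carbonyl, as in compound 2, and the group still carries no net charge. The large size of an at least 8.5-fold lower number from compound 1 to compound 2 (0.93 log units; beyond the scatter) therefore cannot simply be expected to reverse, and compound 3 is expected to stay much nearer to compound 2, perhaps slightly higher. The expected change is small: a 1.7-fold higher number from compound 2 to compound 3 (0.23 log units; within the scatter). For compound 3 the estimated half-life is 0.2 h, with an expected range from 0.07 h to 0.6 h.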

Compound 3, half-life: 0.717 h
Compound 3: middle estimate off by 3.6-fold (0.55 log units), on the low side; the whole stated range lies below it.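

In this assay, the new result reads a 6.1-fold higher number from compound 2 to compound 3 (0.79 log units; beyond the scatter), and this step on the amide-type nitrogen replaces one group bearing a carbonyl and no net charge with another, so among the compounds shown, such a group need not bring the short half-life of compound 2; the two groups differ in where the carbonyl sits, with 1-methyl-2-oxopiperidin-4-yl holding it in the ring and also carrying a methyl on the ring nitrogen. Compound 1 gives > 1 h, a limit of the assay and not a number. The comparison with its 1-methylpiperidin-4-yl group reads an at least 1.3-fold lower number from compound 1 to compound 3 (0.14 log units; that floor lies within the scatter), and the true distance between these two compounds stays unknown because one side of the comparison is only a limit: the limit of > 1 h in this assay, at which 1 of the 3 values shown sits.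

The change from compound 2 to compound 3 moves the carbonyl into the ring and adds the methyl in one step, so the data cannot say which of the two matters more. A 2-oxopiperidin-4-yl group without the methyl, or a 1-methanesulfonylpiperidin-4-yl group, would be needed to separate these features, and its half-life remains an open question.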